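From 4-methoxyphenyl to 3-methoxyphenyl on the shared core

This account rests on a few compounds, and the source may have more. Where it says the series, first, only, none or still open, it means among the compounds named here.

Of the compounds shown here, two on the shared core have so far been tested in a functional assay on MCF7 cells (Homo sapiens) for inhibition, read by sulforhodamine B assay; a higher number here means a weaker inhibitor, a lower number a stronger inhibitor. Compound 1 (`O=C1C(Nc2ccc(C(F)(F)F)cc2)=CC(=O)c2c1nc1n2[C@H]2OC[C@@H](O)[C@H]2OC1`) gives > 4000 nM, which is a limit of the assay and not a number. For the measured compounds named here, compound 2 (`COc1ccc(NC2=CC(=O)c3c(nc4n3[C@H]3OC[C@@H](O)[C@H]3OC4)C2=O)cc1`) gives 4470 nM, the only true number available, so there is no numerical series in which to rank it.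

The untested compound 3 (`COc1cccc(NC2=CC(=O)c3c(nc4n3[C@H]3OC[C@@H](O)[C@H]3OC4)C2=O)c1`) carries 3-methoxyphenyl in place of 4-methoxyphenyl on an amine nitrogen. Going by the values given here, the only measured step that bears on this change is a step that the limit leaves unreadable from compound 1 to compound 2. It swaps trifluoromethyl for methoxy, and because of the limit of > 4000 nM in this assay, at which 1 of the 2 values shown sits, it gives no size to work from. Among the compounds with values here, no measured step moves a methoxy group to another place.

With no evidence for a shift in either direction, no change beyond the usual scatter is expected in this assay, although the wide range allows for one. The expected change is a 1.0-fold higher number from compound 2 to compound 3 (0.00 log units; within the scatter). For compound 3 the estimated value is 4500 nM, with an expected range from 1800 nM to 11000 nM.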

Compound 3, half-maximal inhibitory concentration: 3830 nM
Compound 3: middle estimate off by 1.2-fold (0.07 log units), on the high side, within the range that was stated.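

Moving the methoxy group on the phenyl ring gives the first step at this position that can be read as a size in this assay: a 1.2-fold lower number from compound 2 to compound 3 (0.07 log units; within the scatter), so the two methoxyphenyl isomers cannot be put in any order here. The replacement of 4-(trifluoromethyl)phenyl by 3-methoxyphenyl on the same amine nitrogen reads only as an at least 1.0-fold lower number from compound 1 to compound 3 (0.01 log units; that floor lies within the scatter). That step is only a floor because compound 1 gives a limit and not a number: the limit of > 4000 nM in this assay, at which 1 of the 3 values shown sits.

The compounds shown leave open whether any group on this amine nitrogen can move the value in this assay beyond the scatter, since the only two exact values, those of compound 2 and compound 3, lie within it. From the compounds shown here alone, how a hydroxyl, a chlorine or a dimethylamino group on the phenyl ring, or a plain alkyl chain in place of the phenyl ring, would read in this assay also remains open.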